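Branching the Chain: From Butyl to Isobutyl

The compounds below may be only part of what the source reports. "The series", "measured", "known", "first", "only" and "open" are said of these compounds alone.

Compound 1 `CN1CCC[C@H]1COc1cncc(Cl)c1` gives 0.6 nM in an assay on membranes from brain for displacement of a labelled ligand from Neuronal acetylcholine receptor; alpha4/beta2 (Rattus norvegicus); on this read-out lower numbers stand for stronger inhibition and higher numbers for weaker inhibition.
Compound 2 `CCCCc1cncc(OC[C@@H]2CCCN2C)c1` gives 0.16 nM in this assay.

For the measured compounds named here, compound 2 has the lower of the two numbers measured so far, and its single neighbour is reached by a 3.8-fold lower number from compound 1 to compound 2 (0.57 log units; beyond the scatter), a change of butyl in place of chloro on an aromatic carbon.

Compound 3 `CC(C)Cc1cncc(OC[C@@H]2CCCN2C)c1` has not yet been measured. It differs from compound 2 by isopropyl in place of propyl on a saturated chain carbon bound to an aromatic carbon; the two compounds contain the same atoms, joined differently, so the change is only in the shape of the chain, not in what it is made of.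

Going by the values given here, only one measured step exists, and it exchanged a chloro group for a whole chain rather than reshaping a chain already present. Because a 3.8-fold lower number from compound 1 to compound 2 (0.57 log units; beyond the scatter) concerns a different kind of change, it offers little guidance here, and the expected step is a 1.3-fold higher number from compound 2 to compound 3 (0.10 log units; within the scatter), small enough that it may well fall within the usual scatter. Compound 3 is therefore estimated at 0.2 nM in this assay, within a range from 0.07 nM to 0.6 nM.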

Compound 3, inhibition constant: 0.21 nM
Compound 3: middle estimate off by 1.1-fold (0.02 log units), on the low side, and the stated range covers the measured number.
By their numbers in this assay, from the lowest: compounds 2 and 3 (each within the scatter of the next); then compound 1.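

In this assay, for the compounds shown here, the step from butyl to isobutyl is the first change here that reshapes a chain rather than replacing a chloro group, and it gives a 1.3-fold higher number from compound 2 to compound 3 (0.12 log units; within the scatter) on this saturated chain carbon bound to an aromatic carbon. The straight and branched chains therefore cannot be told apart in this assay, at least for this one rearrangement of the same atoms. The branched chain also stays clearly apart from chloro, with a 2.9-fold lower number from compound 1 to compound 3 (0.46 log units; beyond the scatter) in the same direction as the step to the butyl compound, so both four-carbon chains give lower numbers than compound 1, but nothing measured here explains why the shape of the chain makes so little difference.

On these data alone, whether this tolerance extends further remains open, since a more compact tert-butyl group, a longer chain such as hexyl, or a chain ending in an amine or a carboxylic acid could behave quite differently. The three compounds also cover only this binding read-out, leaving open whether the butyl and isobutyl compounds would stay indistinguishable in a functional test on the same receptor.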